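The source may hold more compounds than are shown below. What is called first, only, known or untested is meant among the compounds shown, and "the series" means these compounds.

In an ADME assay on THP-1 cells (Homo sapiens) for cytotoxicity, read by flow cytometry and propidium iodide staining, with a stated time of 48 h (on this read-out lower numbers stand for higher toxicity in this test and higher numbers for lower toxicity in this test), compound 1, `O=[N+]([O-])c1cc(C(F)(F)F)cc([N+](=O)[O-])c1Nc1ccc(O)cc1`, gives 40000 nM. Compound 2, `O=[N+]([O-])c1cc(C(F)(F)F)cc([N+](=O)[O-])c1Nc1ccccc1O`, gives > 50000 nM, which is a limit of the assay and not a number. Where compound 2 stands is therefore known only as a limit. Among the measured compounds shown here, the one measured step, an at least 1.2-fold higher number from compound 1 to compound 2 (0.09 log units; that floor lies within the scatter), puts 2-hydroxyphenyl in place of 4-hydroxyphenyl, and its floor lies within the scatter. Compound 3, `CN(C)c1c([N+](=O)[O-])cc(C(F)(F)F)cc1[N+](=O)[O-]`, has not yet been measured. It carries dimethylamino in place of (2-hydroxyphenyl)amino on an aromatic carbon, ortho to two nitro groups and para to a trifluoromethyl group: dimethylamino in place of (2-hydroxyphenyl)amino on an aromatic carbon. For the measured compounds named here, no measured step makes this change, so the evidence offers only a weak guide. In this assay, at most a small move toward lower numbers is expected, and the estimated step is an at least 1.2-fold lower number from compound 2 to compound 3 (0.09 log units; that floor lies within the scatter). Compound 3 is expected at 40000 nM, with an estimated range from 15000 nM to 100000 nM.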

Compound 3, half-maximal cytotoxic concentration: > 50000 nM
Compound 3: a limit, no number (the forecaster's own chance of this, stated with the estimate: 40%); middle value at least 1.2-fold (0.09 log units) away from the limit.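

In this assay compound 3 gives > 50000 nM, which is a limit of the assay and not a number. Among the compounds shown here, this shows that the aromatic carbon can carry dimethylamino, with no ring and no hydrogen-bond donors, and still give a limit, a result the earlier compounds showed only with (2-hydroxyphenyl)amino; the comparison with the (4-hydroxyphenyl)amino group of compound 1 gives an at least 1.2-fold higher number from compound 1 to compound 3 (0.09 log units; that floor lies within the scatter). The step from compound 2 to compound 3 cannot be read, because both compounds stand at the same limit: the limit of > 50000 nM in this assay, at which 2 of the 3 values shown sit.

On these data alone, how far compound 2 and compound 3 lie from that limit stays open. So does whether a primary amine, a morpholine or a longer alkyl chain on this aromatic carbon would give a number rather than a limit.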